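The source may hold more compounds than are shown below. What is called first, only, known or untested is meant among the compounds shown, and "the series" means these compounds.

Compound 2 `O=C(CN1CN(c2ccccc2)C2(CCN(C(=O)c3ccc(C4CCCCC4)cc3)CC2)C1=O)NCCCCO` gives 10300 nM in an assay on HEK293 cells for displacement of a labelled ligand from NPC1-like intracellular cholesterol transporter 1 (Homo sapiens) (a higher number here means a weaker inhibitor, a lower number a stronger inhibitor), the larger of the two numbers shown, though only by a 1.6-fold higher number from compound 1 to compound 2 (0.21 log units; within the scatter), where compound 1 `CS(=O)(=O)N1CCN(C(=O)CN2CN(c3ccccc3)C3(CCN(C(=O)c4ccc(C5CCCCC5)cc4)CC3)C2=O)CC1` gives 6300 nM. Compound 3 `O=C(CN1CN(c2ccccc2)C2(CCN(C(=O)c3ccc(C4CCCCC4)cc3)CC2)C1=O)NCO` carries hydroxy in place of 3-hydroxypropyl on a saturated chain carbon bound to an amide-type nitrogen. For the measured compounds named here, the single measured step concerns the same amide-bound substituent and stayed within the scatter, so shortening the hydroxyalkyl chain to a bare hydroxy is not expected to shift this assay beyond the scatter in either direction. Compound 3 is therefore estimated at 11000 nM, with a range of 4500 nM to 28000 nM, an expected step of a 1.1-fold higher number from compound 2 to compound 3 (0.03 log units; within the scatter).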

Compound 3, half-maximal inhibitory concentration: 8300 nM
Estimate against measurement, compound 3: 1.3-fold (0.12 log units) above; measured number inside the range.
By their numbers in this assay, from the lowest: compounds 1, 3 and 2 (each within the scatter of the next).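

Shortening 4-hydroxybutyl to hydroxymethyl in this assay gives no change beyond the scatter (a 1.2-fold lower number from compound 2 to compound 3 (0.09 log units; within the scatter)), so this chain on the amide-type nitrogen can lose its 3-hydroxypropyl portion with no measurable penalty. Replacing the whole 4-(methylsulfonyl)piperazin-1-yl on the carbonyl carbon with (hydroxymethyl)amino likewise stays within the scatter (a 1.3-fold higher number from compound 1 to compound 3 (0.12 log units; within the scatter)). No evidence bears on why these values stay together.

From the compounds shown here alone, whether an amine or a carboxylic acid in place of the hydroxy would separate from these values remains open. So does whether any group at this carbonyl carbon can move the number beyond the scatter.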